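Amine tail variation on a Bcl-2 acylsulfonamide series

The compounds below may be only part of what the source reports. "The series", "measured", "known", "first", "only" and "open" are said of these compounds alone.

Measured so far:
compound 1 `CC1(C)CCC(CN2CCN(c3ccc(C(=O)NS(=O)(=O)c4ccc(NCC5CCOCC5)c([N+](=O)[O-])c4)c(Oc4cnc5[nH]ccc5c4)c3)CC2)=C(c2ccc(Cl)cc2C(F)(F)F)C1` gives 0.86 nM
compound 2 `CC1(C)CCC(CN2CCN(c3ccc(C(=O)NS(=O)(=O)c4ccc(NCC5CCOCC5)c([N+](=O)[O-])c4)c(Oc4cnc5[nH]ccc5c4)c3)CC2)=C(c2ccc(C(F)(F)F)cc2)C1` gives 1.5 nM
compound 3 `CN(C)CCCNc1ccc(S(=O)(=O)NC(=O)c2ccc(N3CCN(CC4=C(c5ccc(C(F)(F)F)cc5)CC(C)(C)CC4)CC3)cc2Oc2cnc3[nH]ccc3c2)cc1[N+](=O)[O-]` gives 0.89 nM

All three were tested in an assay on isolated protein for displacement of a labelled ligand from Apoptosis regulator Bcl-2 (Homo sapiens), with a stated time of 15 min; on this read-out lower numbers stand for stronger inhibition and higher numbers for weaker inhibition. Compound 3 stands second highest of the three numbers; its nearest neighbour is compound 1, from which it is practically indistinguishable, and its furthest is compound 2, yet even that gap is within the scatter. The two single-point steps seen so far are small: a 1.7-fold higher number from compound 1 to compound 2 (0.24 log units; within the scatter) and a 1.7-fold lower number from compound 2 to compound 3 (0.23 log units; within the scatter), neither of them beyond the scatter.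

Compound 4 `CN1CCC(CNc2ccc(S(=O)(=O)NC(=O)c3ccc(N4CCN(CC5=C(c6ccc(C(F)(F)F)cc6)CC(C)(C)CC5)CC4)cc3Oc3cnc4[nH]ccc4c3)cc2[N+](=O)[O-])C1` has not yet been measured. It differs from compound 3 in one place: 1-methylpyrrolidin-3-yl in place of 2-(dimethylamino)ethyl on a saturated chain carbon bound to a nitrogen on an aromatic ring. Within the data shown here, the step that bears on this is the one from compound 2 to compound 3, where the same saturated chain carbon bound to the aromatic nitrogen carried oxan-4-yl and then 2-(dimethylamino)ethyl with only a within-scatter change in the number. A second swap of this same tail, from one amine-bearing group to another, is therefore expected to leave this assay essentially unchanged, with no step beyond the scatter in either direction.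

Compound 4 is estimated at 1 nM, expected to lie between 0.4 nM and 2.5 nM, which corresponds to an expected step of a 1.1-fold higher number from compound 3 to compound 4 (0.05 log units; within the scatter).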

Compound 4, half-maximal inhibitory concentration: 2.4 nM
Beside the measured number, compound 4's estimate is 2.4-fold (0.38 log units) below it; measured number inside the range.
By their numbers in this assay, from the lowest: compounds 1, 3, 2 and 4 (each within the scatter of the next, the first and the last beyond it).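

In this assay, among these compounds, the position on a saturated chain carbon bound to a nitrogen on an aromatic ring proves less indifferent than the earlier compounds suggested: 1-methylpyrrolidin-3-yl in place of 2-(dimethylamino)ethyl gives a 2.7-fold higher number from compound 3 to compound 4 (0.43 log units; beyond the scatter), a modest change but the first step in this set to go beyond the scatter. The same ring set against the oxan-4-yl group gives only a 1.6-fold higher number from compound 2 to compound 4 (0.20 log units; within the scatter), so both amine tails stay within the scatter of the oxan-4-yl compound, and the measurable difference appears only when the two amine tails are compared directly. Nothing available here accounts for the difference seen with this swap.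

Since 1-methylpyrrolidin-3-yl differs from 2-(dimethylamino)ethyl both in having a ring and in its heavy-atom count, the compounds shown cannot separate these two changes, and a longer open amine chain or a 1-methylpiperidin-4-yl group would be needed to tell them apart. From the compounds shown here alone, it also remains open whether the step from the open chain to the ring would recur with the 4-chloro-2-(trifluoromethyl)phenyl group of compound 1 in place of 4-(trifluoromethyl)phenyl.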